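A few compounds are considered here, and "the series" means these few. Any claim that something is new, unique, unknown or untested is made for them only; others in the source may bear on it.

Among the compounds with values here, compound 2 `CCOc1ccccc1OC(C)C1=NCCN1` holds the higher of the two numbers so far in a functional assay on CHO cells for agonist activity at Alpha-2C adrenergic receptor (Homo sapiens); a lower number here means that less compound is needed, a higher number that more compound is needed for the effect: compound 2 gives 10000 nM, while compound 1 `CC(Oc1ccccc1Br)C1=NCCN1` gives 10 nM. Within the data shown here, the only measured step, a 1000-fold higher number from compound 1 to compound 2 (3.00 log units; beyond the scatter), concerns a change on an aromatic carbon, not on the oxygen, so it gives little guidance for the next change. Compound 3 `C=COc1ccccc1OC(C)C1=NCCN1` differs from compound 2 by vinyl in place of ethyl on an oxygen on an aromatic ring. Among the measured compounds shown here, no measured step touches the ethyl itself. For compound 3 a step within the scatter is expected, no change at the digits printed from compound 2 to compound 3 (within the scatter). Compound 3 is therefore estimated at 10000 nM, with a range of 2500 nM to 40000 nM.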

Compound 3, half-maximal effective concentration: 631 nM
The estimate for compound 3 lay 16-fold (1.20 log units) above the measured number, outside the stated range (below it).
By their numbers in this assay, from the lowest: compound 1; then compound 3; then compound 2.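

In this assay, the group on the oxygen is not a silent place: vinyl in place of ethyl gives a 16-fold lower number from compound 2 to compound 3 (1.20 log units; beyond the scatter), though both groups hold the same count of heavy atoms and only vinyl has a double bond outside aromatic rings. Bromo on the aromatic carbon still stands apart, as vinyloxy in its place gives a 63-fold higher number from compound 1 to compound 3 (1.80 log units; beyond the scatter). Nothing measured here accounts for either step.

Open, on these data alone, is whether a longer chain on that oxygen, such as allyl or propyl, tracks with ethyl or with vinyl. Also open, as far as these compounds go, is whether chloro in place of bromo keeps the low number of compound 1.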